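Swapping the Enone Aryl Group: Three Anilides and a Fourth

This account rests on a few compounds, and the source may have more. Where it says the series, first, only, none or still open, it means among the compounds named here.

Compound 1 `O=C(/C=C/c1cccc2ccccc12)c1cccc(NC(=O)c2cc(-c3ccncc3)n[nH]2)c1` carries a naphthalen-1-yl group at the end of the enone chain. In a functional assay, read by spectrophotometry, tested at 100 uM (a lower number here means a stronger inhibitor, a higher number a weaker inhibitor), compound 1 gives 72100 nM. Among the three measured compounds, compound 1 shows the highest number, yet its nearest and furthest neighbours both lie within the scatter, so no order among them can be read. Compound 2 `COc1ccc(/C=C/C(=O)c2cccc(NC(=O)c3cc(-c4ccncc4)n[nH]3)c2)cc1` gives 54600 nM, and compound 3 `CN(C)c1ccc(/C=C/C(=O)c2cccc(NC(=O)c3cc(-c4ccncc4)n[nH]3)c2)cc1` gives 60900 nM in this assay.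

Two measured steps replace the same group at the same place. The step of a 1.3-fold lower number from compound 1 to compound 2 (0.12 log units; within the scatter) and the step of a 1.2-fold lower number from compound 1 to compound 3 (0.07 log units; within the scatter) both stay within the scatter, and the step of a 1.1-fold higher number from compound 2 to compound 3 (0.05 log units; within the scatter) shows that exchanging one para substituent for another also changes little.

Compound 4 `O=C(/C=C/c1ccc([N+](=O)[O-])cc1)c1cccc(NC(=O)c2cc(-c3ccncc3)n[nH]2)c1` is the next such exchange: 4-nitrophenyl in place of naphthalen-1-yl on a double-bonded chain carbon bound to a double-bonded chain carbon. Since the two comparable changes at this place left the number essentially where it was, compound 4 is expected to show no step beyond the scatter, a 1.1-fold lower number from compound 1 to compound 4 (0.05 log units; within the scatter). Compound 4 is therefore estimated at 65000 nM in this assay, with a range from 30000 nM to 140000 nM.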

Compound 4, half-maximal inhibitory concentration: 64600 nM
The estimate for compound 4 lay 1.0-fold (0.00 log units) above the measured number, within the range that was stated.
By their numbers in this assay, from the lowest: compounds 2, 3, 4 and 1 (each within the scatter of the next).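

With compound 4, a third group at this place on a double-bonded chain carbon bound to a double-bonded chain carbon stays within the scatter of naphthalen-1-yl in this assay (a 1.1-fold lower number from compound 1 to compound 4 (0.05 log units; within the scatter)), even though 4-nitrophenyl brings 2 hydrogen-bond acceptors where naphthalen-1-yl has 0. Nitro on the aromatic carbon also cannot be told apart from the two substituents already compared there (a 1.1-fold higher number from compound 3 to compound 4 (0.03 log units; within the scatter); a 1.2-fold higher number from compound 2 to compound 4 (0.07 log units; within the scatter)), so all of the pairs among compounds 1, 2, 3 and 4 now lie within the scatter and these four compounds show no preference among the groups at this place. No independent measurement bears on why the numbers stay so close together.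

On these data alone, what remains open is whether any group at this place can move the number beyond the scatter, such as a carboxylic acid or a primary amine on the phenyl ring, or a saturated alkyl chain in place of the aryl group. These four compounds also share the rest of their structure, so they cannot say whether a change elsewhere in the shared core, such as a methyl group on the amide nitrogen, would matter more.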